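A few compounds are considered here, and "the series" means these few. Any claim that something is new, unique, unknown or untested is made for them only; others in the source may bear on it.

Among the measured compounds shown here, compound 1 `NC(=O)c1ccc(-c2cccnc2)cc1OC1CCNCC1` is one of three compounds measured in an assay on cells for inhibition of MAP kinase-interacting serine/threonine-protein kinase 1 (Homo sapiens), read by mobility shift assay, with stated times of 10 min and 60 min, in the presence of a further agent that is not named here (a lower number here means a stronger inhibitor, a higher number a weaker inhibitor), and in this assay compound 1 gives 1100 nM. This is the highest of the three numbers. The nearest of the other two is compound 2 `CC(C)Oc1cc(-c2cncc(-c3cnn(C)c3)c2)ccc1C(N)=O`, which in this assay gives 400 nM; the furthest is compound 3 `CC(C)Oc1cc(-c2cncc(-c3nn[nH]n3)c2)ccc1C(N)=O`, which gives 310 nM. Both of these gaps lie beyond the scatter, so compound 1 is the weakest inhibitor of the three. For the measured compounds named here, the one step between measured compounds that differ in a single place, a 1.3-fold lower number from compound 2 to compound 3 (0.11 log units; within the scatter), concerns a change on the pyridine rather than on the oxygen, and is within the scatter.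

Compound 4 `NC(=O)c1ccc(-c2cccnc2)cc1O` differs from compound 1 in one place: hydrogen in place of piperidin-4-yl on an oxygen on an aromatic ring. Going by the values given here, no measured pair shows this change, or any change at this oxygen, so there is no step that bears on it directly. Compounds 2 and 3 carry a different group on the same oxygen together with a further change on the pyridine, and their numbers cannot be separated into the two parts. What remains is the size of the group that leaves. Compound 4 is therefore expected to be a weaker inhibitor than compound 1, with an expected 3.2-fold higher number from compound 1 to compound 4 (0.50 log units; beyond the scatter). Compound 4 is estimated at 3500 nM, within a range from 1000 nM to 12000 nM.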

Compound 4, half-maximal inhibitory concentration: 4300 nM
The estimate for compound 4 lay 1.2-fold (0.09 log units) below the measured number; low and high end bracket the measured number.
By their numbers in this assay, from the lowest: compounds 3 and 2 (each within the scatter of the next); then compound 1; then compound 4.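

Among the compounds shown here, the first direct reading at this oxygen comes from hydrogen taking the place of piperidin-4-yl: in this assay this change gives a 3.9-fold higher number from compound 1 to compound 4 (0.59 log units; beyond the scatter). For the compounds shown here, the earlier compounds could not show this, since compound 2 and compound 3 differ from compound 1 in more than one place, and the only step among them concerns a different position. The step shows that the number in this assay does respond to what sits on this oxygen, yet the response is modest, and compound 4, with only a hydroxy there, still gives a measured 4300 nM; nothing in the data given accounts for the rise.

With only these two groups compared directly on this oxygen, the compounds shown do not tell whether the difference follows the ring as a whole or its nitrogen, a question that a cyclohexyl group, without that nitrogen, or an open chain bearing an amine, such as 2-aminoethyl, would address on the same core. From the compounds shown here alone, whether a small group such as methyl would fall nearer compound 1 or compound 4 also stays open.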